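The source may hold more compounds than are shown below. What is called first, only, known or untested is meant among the compounds shown, and "the series" means these compounds.

Compound 3 `COc1ccc(-c2cc(NNC(=O)Nc3cc(Cl)nc(Cl)c3)nc3c2c(C)nn3C)cc1` gives 1020 nM in an assay on isolated protein for binding affinity to sphingosine 1-phosphate receptor 2 (Homo sapiens), read by surface plasmon resonance (a higher number here means weaker binding, a lower number tighter binding), the second highest of the three numbers, nearest to compound 2 `Cc1nn(C)c2nc(NNC(=O)Nc3cc(Cl)nc(Cl)c3)cc(-c3ccc(F)cc3)c12` with 980 nM and furthest from compound 1 `Cc1nn(C)c2nc(NNC(=O)Nc3cc(Cl)nc(Cl)c3)cc(-c3ccc(Cl)s3)c12` with 1980 nM. Of the measured steps, a 1.0-fold higher number from compound 2 to compound 3 (0.02 log units; within the scatter) and a 1.9-fold lower number from compound 1 to compound 3 (0.29 log units; within the scatter) lie within the scatter, while a 2.0-fold lower number from compound 1 to compound 2 (0.31 log units; beyond the scatter) is modest. Compound 4 `Cc1cc(NNC(=O)Nc2cc(Cl)nc(Cl)c2)nc2c1c(C)nn2C` differs from compound 3 in one place: methyl in place of 4-methoxyphenyl on an aromatic carbon. Among the measured compounds shown here, every measured step merely swaps one aryl group for another, and the three numbers stay close together; none removes the six-membered aromatic ring altogether, so no step bears directly on this change. The step expected here, a 2.5-fold higher number from compound 3 to compound 4 (0.39 log units; beyond the scatter), is therefore a cautious guess toward somewhat weaker binding. Compound 4 is estimated at 2500 nM, within a range of 1000 nM to 6500 nM.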

Compound 4, dissociation constant: 11000 nM
Beside the measured number, compound 4's estimate is 4.4-fold (0.64 log units) below it; the measured number lies above the stated range.
By their numbers in this assay, from the lowest: compounds 2, 3 and 1 (each within the scatter of the next, the first and the last beyond it); then compound 4.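

On the aromatic carbon opposite the ring nitrogen, replacing an aryl group with methyl matters far more than exchanging one aryl group for another. Among the compounds shown here, this holds for 4-methoxyphenyl (an 11-fold higher number from compound 3 to compound 4 (1.03 log units; beyond the scatter)), 4-fluorophenyl (an 11-fold higher number from compound 2 to compound 4 (1.05 log units; beyond the scatter)) and, less strongly, 5-chlorothiophen-2-yl (a 5.6-fold higher number from compound 1 to compound 4 (0.74 log units; beyond the scatter)), with no compound going against it. Nothing available explains this loss of binding.

Going by these compounds, it remains open whether a longer chain such as n-butyl would bind like methyl. The same question stands for a saturated ring such as cyclohexyl, and whether it would instead match the aryl groups.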